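Hydroxyphenyl to hydroxyquinolinyl on the shared core

The source may hold more compounds than are shown below. What is called first, only, known or untested is meant among the compounds shown, and "the series" means these compounds.

Measured compounds:
compound 1 `COc1ccc(-c2c3ccc4ccccc4c3nc3c2c(C)nc2c4ccccc4ccc32)cc1` — 45900 nM
compound 2 `Cc1nc2c3ccccc3ccc2c2nc3c(ccc4ccccc43)c(-c3ccc(O)cc3)c12` — 4630 nM

In a functional assay on HeLa cells (Homo sapiens) for cytotoxicity, read by MTT assay, with a stated time of 48 h (a lower number here means a stronger inhibitor, a higher number a weaker inhibitor), compound 1 gives 45900 nM. Going by the values given here, compound 2 gives 4630 nM in this assay, the lowest of the two numbers recorded so far, with compound 1 as its only neighbour. Among the compounds with values here, the single step that has been measured, a 9.9-fold lower number from compound 1 to compound 2 (1.00 log units; beyond the scatter), concerns hydrogen in place of methyl on an oxygen on an aromatic ring and nothing else.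

Compound 3 `Cc1nc2c3ccccc3ccc2c2nc3c(ccc4ccccc43)c(-c3cc(O)nc4ccccc34)c12` is now to be measured in this assay. It differs from compound 2 by 2-hydroxyquinolin-4-yl in place of 4-hydroxyphenyl on an aromatic carbon, placed on an aromatic carbon of a six-membered aromatic ring with one nitrogen, part of a fused system of six rings, opposite the ring nitrogen. Within the data shown here, no measured step bears on this exchange; the one step known changes only the substituent on oxygen, not the aromatic group itself. Among the measured compounds shown here, with no comparable precedent, no direction beyond the scatter is expected, and the estimated step is a 1.1-fold higher number from compound 2 to compound 3 (0.03 log units; within the scatter). For compound 3 the expected value is 5000 nM, within a range from 1500 nM to 16000 nM.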

Compound 3, half-maximal inhibitory concentration: 4880 nM
The estimate for compound 3 lay 1.0-fold (0.01 log units) above the measured number, and the stated range covers the measured number.
By their numbers in this assay, from the lowest: compounds 2 and 3 (each within the scatter of the next); then compound 1.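

At this place on the shared core, opposite the ring nitrogen, 2-hydroxyquinolin-4-yl and 4-hydroxyphenyl cannot be told apart in this assay, with a 1.1-fold higher number from compound 2 to compound 3 (0.02 log units; within the scatter), so the larger group, with its second six-membered aromatic ring and ring nitrogen, is accommodated without a readable shift. Set against 4-methoxyphenyl, the same group gives a 9.4-fold lower number from compound 1 to compound 3 (0.97 log units; beyond the scatter), which places compound 2 and compound 3, the two carrying a hydroxy group, together and apart from compound 1. Nothing available explains why the two hydroxy-bearing groups read alike.

Open, going by these compounds, is whether 2-methoxyquinolin-4-yl would fall with compound 1 or with compound 3, which would test the hydroxy group on this second aryl group. Also open, on these data alone, is how an amine or a carboxylic acid in place of that hydroxy group would read in this assay.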